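From methoxymethyl to a cyclobutylcarbamoyl side chain

A few compounds are considered here, and "the series" means these few. Any claim that something is new, unique, unknown or untested is made for them only; others in the source may bear on it.

In a functional assay on OVCAR-8 cells (Homo sapiens) for antiproliferative activity (on this read-out lower numbers stand for stronger inhibition and higher numbers for weaker inhibition), three compounds with a shared core have been measured. Compound 1 (`Cn1ncc(Cl)c1-c1cc(C(=O)N[C@@H]2CN[C@H](CCN3CCCCC3)C[C@H]2c2ccc(Cl)c(Cl)c2)oc1Cl`) gives 1660 nM, compound 2 (`Cn1ncc(Cl)c1-c1cc(C(=O)N[C@@H]2CN[C@H](CC(=O)NCC(O)CO)C[C@H]2c2ccc(Cl)c(Cl)c2)oc1Cl`) gives 5900 nM, and compound 3 (`COCC[C@@H]1C[C@@H](c2ccc(Cl)c(Cl)c2)[C@H](NC(=O)c2cc(-c3c(Cl)cnn3C)c(Cl)o2)CN1`) gives 1060 nM. Compound 3 and compound 1 share the low end of these numbers, the step between them being a 1.6-fold lower number from compound 1 to compound 3 (0.19 log units; within the scatter).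

Compound 4 (`Cn1ncc(Cl)c1-c1cc(C(=O)N[C@@H]2CN[C@H](CC(=O)NC3CCC3)C[C@H]2c2ccc(Cl)c(Cl)c2)oc1Cl`) carries cyclobutylcarbamoyl in place of methoxymethyl on a saturated chain carbon bound to a saturated ring carbon.

For the measured compounds named here, the nearest precedent is compound 2, the only measured compound with a carbamoyl group on that carbon. Its steps are a 5.6-fold lower number from compound 2 to compound 3 (0.75 log units; beyond the scatter) and a 3.6-fold higher number from compound 1 to compound 2 (0.55 log units; beyond the scatter), both modest. Nothing measured shows how cyclobutyl compares with 2,3-dihydroxypropyl on the carbamoyl group, so only part of that gap is expected to carry over in this assay. The expected change is a modest one towards a higher number: a 2.1-fold higher number from compound 3 to compound 4 (0.32 log units; beyond the scatter). Compound 4 is estimated at 2200 nM, with an expected range of 1000 nM to 5000 nM.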

Compound 4, half-maximal inhibitory concentration: 610 nM
For compound 4 the middle estimate is 3.6-fold (0.56 log units) above the measured one, outside the stated range (below it).
By their numbers in this assay, from the lowest: compounds 4, 3 and 1 (each within the scatter of the next, the first and the last beyond it); then compound 2.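

Cyclobutylcarbamoyl on a saturated chain carbon bound to a saturated ring carbon is tolerated in this assay, with a step that stays within the scatter (a 1.7-fold lower number from compound 3 to compound 4 (0.24 log units; within the scatter)), so a carbamoyl group at this position does not by itself bring the high number of compound 2. With the carbamoyl group held in place, the group on the amide-type nitrogen makes a clear difference (a 9.7-fold lower number from compound 2 to compound 4 (0.99 log units; beyond the scatter)), and cyclobutylcarbamoyl also reads beyond the scatter against the (piperidin-1-yl)methyl group (a 2.7-fold lower number from compound 1 to compound 4 (0.43 log units; beyond the scatter)). No available evidence accounts for these differences.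

The compounds shown leave open how cyclopropyl or cyclohexyl on the amide-type nitrogen would read. They also leave open how a dimethylcarbamoyl group or a carboxylic acid would read on that saturated chain carbon.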